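Swapping the Aryl Ketone Ring in a Fused Triazole Series

This account rests on a few compounds, and the source may have more. Where it says the series, first, only, none or still open, it means among the compounds named here.

Measured so far:
compound 1 `COc1cc(-c2nnc3n2NC(c2ccco2)C(C(=O)c2ccccc2)S3)cc(OC)c1OC`: 64300 nM
compound 2 `COc1cc(-c2nnc3n2NC(c2ccco2)C(C(=O)c2ccc(F)c(F)c2)S3)cc(OC)c1OC`: 36000 nM

Compound 1 and compound 2 share one core and differ only in the ring attached to the carbonyl carbon. In a functional assay on PC-3 cells (Homo sapiens) for cytotoxicity, read by MTT assay, with a stated time of 48 h (on this read-out lower numbers stand for stronger inhibition and higher numbers for weaker inhibition), compound 1 gives 64300 nM, and in the same test compound 2 gives 36000 nM. Among the compounds with values here, the one measured step, a 1.8-fold lower number from compound 1 to compound 2 (0.25 log units; within the scatter), is within the scatter of repeated measurements, so the two numbers cannot be told apart, and compound 2 stands level with compound 1 rather than ahead of it.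

Compound 3 `COc1cc(-c2nnc3n2NC(c2ccco2)C(C(=O)c2ccc(C(F)(F)F)cc2)S3)cc(OC)c1OC` is not yet measured. It differs from compound 2 in one place: 4-(trifluoromethyl)phenyl in place of 3,4-difluorophenyl on a carbonyl carbon. Within the data shown here, the only step that bears on this change is the one from compound 1 to compound 2, which swapped one aromatic ring on the carbonyl carbon for another with fluorine substitution and produced no change beyond the scatter. With just one such step, and that one flat, there is no ground to expect a move in either direction. The expected step is a 1.1-fold higher number from compound 2 to compound 3 (0.02 log units; within the scatter), which is nothing beyond the scatter. Compound 3 is therefore estimated to give about 38000 nM in this assay, within a range from 15000 nM to 95000 nM.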

Compound 3, half-maximal inhibitory concentration: 77500 nM
Compound 3: the middle estimate sits 2.0-fold (0.31 log units) below what was measured; the measured number falls inside the stated range.
By their numbers in this assay, from the lowest: compounds 2, 1 and 3 (each within the scatter of the next, the first and the last beyond it).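

In this assay the ring on the carbonyl carbon now gives a step beyond the scatter, with a 2.2-fold higher number from compound 2 to compound 3 (0.33 log units; beyond the scatter) when 4-(trifluoromethyl)phenyl takes the place of 3,4-difluorophenyl. The step is modest, so this position responds to the choice of ring only slightly among the compounds shown. Set against the plain phenyl ring of compound 1, the added trifluoromethyl group gives a 1.2-fold higher number from compound 1 to compound 3 (0.08 log units; within the scatter) and so cannot be told apart from hydrogen, which means that only the two fluorine-bearing rings differ from each other, while neither differs from phenyl beyond the scatter. Nothing available explains why these two rings differ.

All three rings are aromatic rings of carbon only, bearing nothing but hydrogen, fluorine or trifluoromethyl, so the compounds shown leave open what an amine, a carboxylic acid or a methoxy group on this ring would do. They also leave open whether a pyridine ring on the carbonyl carbon, with nitrogen in the ring itself, would move the number beyond the scatter from compound 1.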